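From Chloro to Nitrooxy: An Untested Exchange

The source may hold more compounds than are shown below. What is called first, only, known or untested is meant among the compounds shown, and "the series" means these compounds.

Of the compounds shown here, two have so far been measured in a functional assay on HCT-116 cells (Homo sapiens) for antiproliferative activity, read by CCK-8 assay and cell counting, with a stated time of 72 h; a higher number here means a weaker inhibitor, a lower number a stronger inhibitor. In this assay, compound 1 `O=C(Nc1ccccc1OC(=O)c1ccc(CCl)cc1)c1ccc(CCl)cc1` gives 600 nM. Compound 2 `O=C(Nc1ccccc1)c1ccc(CCl)cc1`, which also carries chloromethyl, gives 1200 nM. These two numbers lie within the usual scatter of repeated measurements, so compound 2 stands level with compound 1 and the pair cannot be ranked.

Compound 3 `O=C(Nc1ccccc1)c1ccc(CO[N+](=O)[O-])cc1` is compound 2 with a single exchange: nitrooxy in place of chloro on a saturated chain carbon bound to an aromatic carbon. Among the compounds with values here, no measured pair shows what this exchange does, because both measured compounds hold chloromethyl. Within the data shown here, the only direct reference is compound 2 at 1200 nM, so any forecast stays loose. A modest move towards a weaker inhibitor is expected, though a result within the scatter remains possible, and the estimated change is a 2.1-fold higher number from compound 2 to compound 3 (0.32 log units; beyond the scatter). In this assay, the estimated value for compound 3 is 2500 nM, with an expected range from 500 nM to 15000 nM.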

Compound 3, half-maximal inhibitory concentration: 600 nM
The estimate for compound 3 lay 4.2-fold (0.62 log units) above the measured number; low and high end bracket the measured number.
By their numbers in this assay, from the lowest: compounds 1, 3 and 2 (each within the scatter of the next).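

The exchange of chloro for nitrooxy on a saturated chain carbon bound to an aromatic carbon gives a 2.0-fold lower number from compound 2 to compound 3 (0.30 log units; within the scatter) in this assay. Within the data shown here, this is the first measured pair to isolate this place, and it shows that the chlorine of compound 2 can be replaced, here by a group of 4 heavy atoms with 3 hydrogen-bond acceptors, without the two compounds separating in this read-out, so antiproliferative activity at this level does not depend on chloromethyl in this pair. No independent measurement is available to explain this result, which therefore stands as an observation only.

The pair does not show whether this place needs a reactive-looking or heteroatom-bearing group at all, and a plain methyl, a hydroxymethyl or an aminomethyl group here would test that directly. It also leaves open whether the same exchange of chloromethyl to (nitrooxy)methyl would hold in the larger compound 1, and whether a longer chain carrying the nitrooxy group would keep the number in the same range.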